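Nitro in Place of Methyl on a Chalcone Sulfonamide

This account rests on a few compounds, and the source may have more. Where it says the series, first, only, none or still open, it means among the compounds named here.

Going by the values given here, compound 2 `Cc1ccc(/C=C/C(=O)c2ccc(NS(=O)(=O)c3ccc(C)cc3)cc2)cc1` gives 49800 nM in a functional assay on HepG2 cells (Homo sapiens) for cytotoxicity, read by sulforhodamine B assay, with a stated time of 48 h (a lower number here means a stronger inhibitor, a higher number a weaker inhibitor), the highest of the two numbers so far; compound 1 `Cc1ccc(S(=O)(=O)Nc2ccc(C(=O)/C=C/c3ccc(Cl)cc3)cc2)cc1` gives 43300 nM, within the scatter of it. Compound 3 `Cc1ccc(S(=O)(=O)Nc2ccc(C(=O)/C=C/c3ccc([N+](=O)[O-])cc3)cc2)cc1` differs from compound 2 by nitro in place of methyl on an aromatic carbon. Among the compounds with values here, the only measured step touching the same aromatic carbon, a 1.2-fold higher number from compound 1 to compound 2 (0.06 log units; within the scatter), stayed within the scatter, and no measured step involves a nitro group. Compound 3 is therefore expected to give about 45000 nM, between 18000 nM and 110000 nM. This estimate means a step of a 1.1-fold lower number from compound 2 to compound 3 (0.04 log units; within the scatter), expected to stay within the scatter.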

Compound 3, half-maximal inhibitory concentration: 26000 nM
For compound 3 the middle estimate is 1.7-fold (0.24 log units) above the measured one, and the stated range covers the measured number.
By their numbers in this assay, from the lowest: compounds 3, 1 and 2 (each within the scatter of the next).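

In this assay, nitro in place of methyl gives a 1.9-fold lower number from compound 2 to compound 3 (0.28 log units; within the scatter) and nitro in place of chloro gives a 1.7-fold lower number from compound 1 to compound 3 (0.22 log units; within the scatter). This place on the aromatic ring therefore takes a group with two hydrogen-bond acceptors and still gives numbers within the scatter, which the methyl and chloro pair alone could not show. Nothing shown here offers a reason for this reading. From the compounds shown here alone, whether an amine, a carboxylic acid or a longer chain at this place would give a step beyond the scatter remains open.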